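From Hexyl to Isopentyl on Compound 2

The source may hold more compounds than are shown below. What is called first, only, known or untested is meant among the compounds shown, and "the series" means these compounds.

In a functional assay on MCF7 cells (Homo sapiens) for inhibition, read by fluorescence, with a stated time of 72 h (on this read-out higher numbers stand for weaker inhibition of growth and lower numbers for stronger inhibition of growth), compound 2 `CCCCCCn1cnc2c(Nc3ccc(O)cc3)nc(N[C@H]3CC[C@H](N)CC3)nc21` gives 3500 nM and compound 1 `CCCCCCn1cnc2c(Nc3cc(OC)cc(OC)c3)nc(N[C@H]3CC[C@H](N)CC3)nc21` gives 3500 nM at the same level, while compound 3 `CCCCCCn1cnc2c(Nc3cccc(Cl)c3)nc(N[C@H]3CC[C@H](N)CC3)nc21` gives 2700 nM within the scatter of both. Compound 4 `CC(C)CCn1cnc2c(Nc3ccc(O)cc3)nc(N[C@H]3CC[C@H](N)CC3)nc21` differs from compound 2 by isopropyl in place of butyl on a saturated chain carbon, two bonds along the chain from an aromatic nitrogen and the same difference, cut one bond further out, reads hexyl to isopentyl. For the measured compounds named here, the only measured steps are no change at the digits printed from compound 1 to compound 2 (within the scatter) and a 1.3-fold lower number from compound 1 to compound 3 (0.11 log units; within the scatter) and a 1.3-fold lower number from compound 2 to compound 3 (0.11 log units; within the scatter) and all of them replace the aromatic group on a nitrogen, leaving the chain untouched. They therefore offer only indirect guidance. The expected step is a 1.1-fold higher number from compound 2 to compound 4 (0.06 log units; within the scatter) and none beyond the scatter is anticipated in this assay for this change. The estimate for compound 4 is 4000 nM with 1800 nM to 9000 nM as its expected range.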

Compound 4, concentration for 50% growth inhibition: 3100 nM
Compound 4: the middle estimate sits 1.3-fold (0.11 log units) above what was measured; the range from low to high includes it.
By their numbers in this assay, from the lowest: compounds 3, 4, 1 and 2 (each within the scatter of the next).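

For the compounds shown here, until now every step in this assay replaced the aromatic group on a nitrogen; this is the first reading at the chain, where isopropyl in place of butyl gives a 1.1-fold lower number from compound 2 to compound 4 (0.05 log units; within the scatter) and stays within the scatter. With 4-hydroxyphenyl on the nitrogen, then, hexyl and isopentyl cannot be told apart on this read-out. Nothing measured here bears on the reason for this result.

On these data alone, whether an octyl chain, or a chain ending in an amine or a carboxylic acid, would read differently at this position remains open. So does whether hexyl and isopentyl also match with 3-chlorophenyl on the nitrogen.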